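The source may report more compounds than this note shows. Statements on the series, on what has been measured and on what is new or still open speak of the compounds shown alone.

In a functional assay on MCF7 cells (Homo sapiens) for antiproliferative activity, read by sulforhodamine B assay, with a stated time of 48 h (a higher number here means a weaker inhibitor, a lower number a stronger inhibitor), compound 1 (`CCCN1CCN(c2ccc(S(=O)(=O)Oc3ccccc3OC)cc2)C1=O`) gives 13000 nM. Compound 2 (`CCCN1CCN(c2ccc(S(=O)(=O)Oc3c(Cl)cc(Cl)cc3Cl)cc2)C1=O`) has no number in this series, only a limit of the assay: > 100000 nM. Among the measured compounds shown here, the single measured step is an at least 7.6-fold higher number from compound 1 to compound 2 (0.88 log units; beyond the scatter), with 2,4,6-trichlorophenyl in place of 2-methoxyphenyl on an oxygen. Compound 3 (`CCCN1CCN(c2ccc(S(=O)(=O)Oc3cccc(Cl)c3)cc2)C1=O`) changes that same place, with 3-chlorophenyl in place of 2,4,6-trichlorophenyl on an oxygen. For the measured compounds named here, with only that step to go on, and with compound 2 held at a limit, its true size stays open. Still, leaving the 2,4,6-trichlorophenyl group is expected to reverse at least a modest part of an at least 7.6-fold higher number from compound 1 to compound 2 (0.88 log units; beyond the scatter), moving this assay towards a lower number. The expected change is an at least 5.0-fold lower number from compound 2 to compound 3 (0.69 log units; beyond the scatter). For compound 3 the estimated value is 20000 nM, with an expected range from 4000 nM to 90000 nM.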

Compound 3, half-maximal inhibitory concentration: 380 nM
For compound 3 the middle estimate is 53-fold (1.72 log units) above the measured one; measured number below the stated range.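

The place on the oxygen bound to the sulfonyl sulfur can carry a gain as well as a loss: in this assay, 3-chlorophenyl in place of 2,4,6-trichlorophenyl gives an at least 260-fold lower number from compound 2 to compound 3 (2.42 log units; beyond the scatter). The same group also goes well past the earlier 2-methoxyphenyl compound, with a 34-fold lower number from compound 1 to compound 3 (1.53 log units; beyond the scatter), so this change does more than win back what the 2,4,6-trichlorophenyl group lost. The first of these steps gives only a lower bound on its size, because compound 2 sits at a limit of the assay: the limit of > 100000 nM in this assay, at which 1 of the 3 values shown sits.

On these data alone, whether the gain rests on the single chlorine itself stays open, as a plain phenyl or a 3-methoxyphenyl group would be needed at this place to tell. Also open, as far as these compounds go, is whether 3-chlorophenyl keeps this advantage on a core with a longer chain.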